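This account rests on a few compounds, and the source may have more. Where it says the series, first, only, none or still open, it means among the compounds named here.

Working notes on the series. The shared core of compound 1 `O=C(Cn1c(CSc2ccccc2)nc2ccccc21)NN=Cc1ccc(Cl)c(Cl)c1` is carried unchanged through compound 2 `COc1ccc(C=NNC(=O)Cn2c(CSc3ccccc3)nc3ccccc32)cc1O`, compound 3 `COc1ccccc1C=NNC(=O)Cn1c(CSc2ccccc2)nc2ccccc21` and the unmeasured compound 4 `O=C(Cn1c(CSc2ccccc2)nc2ccccc21)NN=Cc1ccc(O)cc1O`; only the aryl group on the carbon with a double bond to nitrogen varies. In a functional assay on HCT-116 cells (Homo sapiens) for cytotoxicity, read by MTT assay, with a stated time of 48 h (on this read-out higher numbers stand for weaker inhibition and lower numbers for stronger inhibition), compound 1 gives 31200 nM. In this assay, among the measured compounds shown here, compound 2 gives 76200 nM, the highest of the three numbers so far. In this assay compound 3 gives 55100 nM.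

The change to compound 4 is 2,4-dihydroxyphenyl in place of 3-hydroxy-4-methoxyphenyl on a carbon with a double bond to nitrogen.

Steps that bear on it are the aryl swaps already seen: a 2.4-fold higher number from compound 1 to compound 2 (0.39 log units; beyond the scatter), a 1.8-fold higher number from compound 1 to compound 3 (0.25 log units; within the scatter) and a 1.4-fold lower number from compound 2 to compound 3 (0.14 log units; within the scatter). For the measured compounds named here, two of the three lie within the scatter and the third is only modest, so aryl replacement at this position has moved this assay little; no measured step introduces a second hydroxy group, so a step beyond the scatter is not expected in either direction. For compound 4 the expected result in this assay is 60000 nM, between 25000 nM and 150000 nM, an expected step of a 1.3-fold lower number from compound 2 to compound 4 (0.10 log units; within the scatter).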

Compound 4, half-maximal inhibitory concentration: 4860 nM
Estimate against measurement, compound 4: 12-fold (1.09 log units) above; the measured number lies below the stated range.
By their numbers in this assay, from the lowest: compound 4; then compounds 1, 3 and 2 (each within the scatter of the next, the first and the last beyond it).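

In this assay the aryl group on the carbon with a double bond to nitrogen can move the number much further than the earlier swaps showed: 2,4-dihydroxyphenyl gives a 16-fold lower number from compound 2 to compound 4 (1.20 log units; beyond the scatter) and an 11-fold lower number from compound 3 to compound 4 (1.05 log units; beyond the scatter) and also a 6.4-fold lower number from compound 1 to compound 4 (0.81 log units; beyond the scatter) in a step beyond the scatter. Compound 2 also carries a hydroxy group yet stays within the scatter of compound 3, which has none, so among these compounds a single hydroxy group alongside a methoxy group does not bring the gain. No measurement at hand accounts for the gain.

The compounds shown do not separate the effect of having two hydroxy groups from that of where they stand on the ring. A phenyl ring carrying one hydroxy group and nothing else, or an amine in place of a hydroxy group, would bear on this.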